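A few compounds are considered here, and "the series" means these few. Any claim that something is new, unique, unknown or untested is made for them only; others in the source may bear on it.

Series notes. In a functional assay on T-24 cells (Homo sapiens) for cytotoxicity, read by CCK-8 assay, with a stated time of 24 h (on this read-out higher numbers stand for weaker inhibition and lower numbers for stronger inhibition), compound 1 `C/C(=C\c1cc(-c2ccccc2)cs1)C(N)=O` gives only the assay limit > 50000 nM. Compound 2 `COc1ccc(-c2csc(/C=C(\C)C(N)=O)c2)cc1` likewise gives only the limit > 50000 nM in this assay, so its standing cannot be placed more closely than that. Within the data shown here, the single measured step, a step that the two limits leave unreadable from compound 1 to compound 2, is unreadable because both of its values sit at the limit of > 50000 nM in this assay, at which 2 of the 2 values shown sit. Compound 3 `C=Cc1ccc(-c2csc(/C=C(\C)C(N)=O)c2)cc1` carries vinyl in place of methoxy on an aromatic carbon, that is vinyl in place of methoxy on an aromatic carbon, para to a large group. With no readable step to lean on, no direction is expected for a step that the limit leaves unreadable from compound 2 to compound 3. Compound 3 is therefore expected near 60000 nM, between 20000 nM and 200000 nM, most probably again reported only as a limit.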

Compound 3, half-maximal inhibitory concentration: > 50000 nM
Compound 3 gave a limit, no number; the forecaster's own chance of this, stated with the estimate: 80%; the middle value does not contradict the limit.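

No new step can be read among compound 1, compound 2 and compound 3, because all their values are limits and not numbers: the limit of > 50000 nM in this assay, at which 3 of the 3 values shown sit. The compounds shown leave open whether hydrogen, methoxy or vinyl on that aromatic carbon makes any difference in this assay.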